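Lengthening a methyl to hexyl on a shared indole-free core

A few compounds are considered here, and "the series" means these few. Any claim that something is new, unique, unknown or untested is made for them only; others in the source may bear on it.

Three compounds built on the shared core of compound 1 `CCCCCCc1ccc2[nH]c(-c3ccccc3)c(C3=C(Br)C(=O)NC3=O)c2c1` have been measured in a physicochemical assay for lipophilicity; on this read-out lower numbers stand for lower lipophilicity and higher numbers for higher lipophilicity. Compound 1 gives 4.39. Compound 2 `CCCCCCOc1ccc2[nH]c(-c3cccc(OC)c3)c(C3=C(Br)C(=O)NC3=O)c2c1` gives 3.92. Compound 3 `COc1cccc(-c2[nH]c3ccc(C)cc3c2C2=C(Br)C(=O)NC2=O)c1` gives 3.12, the lowest of the three numbers and beyond the scatter from both of the others; the move from compound 2 to compound 3, methyl in place of hexyloxy on an aromatic carbon, reads a number 0.80 log units lower from compound 2 to compound 3 (beyond the scatter).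

Compound 4 `CCCCCCc1ccc2[nH]c(-c3cccc(OC)c3)c(C3=C(Br)C(=O)NC3=O)c2c1` has not yet been measured in this assay. It differs from compound 3 by pentyl in place of hydrogen on a saturated chain carbon bound to an aromatic carbon. Going by the values given here, the only measured step that bears on this change is the one from compound 2 to compound 3, which removed a chain of similar length and lowered the number modestly; compound 1, which carries the hexyl chain with an unsubstituted phenyl, also sits well above compound 3. The expected step from compound 3 to compound 4 is therefore an increase of about a number 1.08 log units higher from compound 3 to compound 4 (beyond the scatter), beyond the scatter. Compound 4 is estimated at 4.2, with a range from 3.75 to 4.65.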

Compound 4, partition coefficient: 4.26
Compound 4: the middle estimate sits 0.06 log units below what was measured, and the stated range covers the measured number.
By their numbers in this assay, from the lowest: compound 3; then compound 2; then compounds 4 and 1 (each within the scatter of the next).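

In this assay, going by these compounds alone, the step of a number 1.14 log units higher from compound 3 to compound 4 (beyond the scatter) gives the first reading of methyl to hexyl at this place with nothing else changed, and it is large. Hexyl and hexyloxy, compared on an aromatic carbon, also prove distinguishable, with a number 0.34 log units higher from compound 2 to compound 4 (beyond the scatter) lying beyond the scatter, so the earlier drop on going from hexyloxy to methyl did not depend on chain length alone. With hexyl in place, methoxy in place of hydrogen on an aromatic carbon gives a number 0.13 log units lower from compound 1 to compound 4 (within the scatter) and stays within the scatter, so this change has no readable effect in this setting.

Going by these compounds, how the number moves at chain lengths between methyl and hexyl, with a longer chain such as octyl, or with an amine or a carboxylic acid at the chain end remains open. No supporting evidence accounts for any of these steps.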